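The compounds below may be only part of what the source reports. "The series", "measured", "known", "first", "only" and "open" are said of these compounds alone.

Working notes on the series. Two compounds have numbers in an assay on isolated protein for inhibition of serine protease 1 (Bos taurus); a higher number here means a weaker inhibitor, a lower number a stronger inhibitor. Compound 1 `CC(=N)N1CCC(Oc2ccc3nc(C(C)C)n(Cc4ccc5ccc(C(=N)N)cc5c4)c3c2)CC1` gives 5.7 nM in this assay. Compound 2 `CC(=N)N1CCC(Oc2ccc3c(c2)nc(CCC(=O)O)n3Cc2ccc3ccc(C(=N)N)cc3c2)CC1` gives 14 nM in this assay. Compound 1 stands with the lower of the two numbers; the nearest to it is compound 2, and that gap is beyond the usual scatter. Within the data shown here, no pair of measured compounds differs in a single place, so no measured single-change step is available to lean on.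

Compound 3 `CCc1nc2ccc(OC3CCN(C(C)=N)CC3)cc2n1Cc1ccc2ccc(C(=N)N)cc2c1` has not yet been measured in this assay. It differs from compound 1 in one place: hydrogen in place of methyl on a saturated chain carbon bound to an aromatic carbon and a saturated chain carbon. Cut one bond further out, the change reads isopropyl to ethyl, and it otherwise leaves the shared core of compound 1 untouched.

Among the measured compounds shown here, with no measured step of this type, the expectation rests on the change being small. The step from compound 1 to compound 3 is expected to be a 1.4-fold higher number from compound 1 to compound 3 (0.15 log units; within the scatter), in the weaker direction if any, and it may well fall within the scatter. Compound 3 is estimated at 8 nM in this assay, with a range from 3 nM to 22 nM.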

Compound 3, inhibition constant: 7.7 nM
Compound 3: middle estimate off by 1.0-fold (0.02 log units), on the high side; low and high end bracket the measured number.
By their numbers in this assay, from the lowest: compounds 1, 3 and 2 (each within the scatter of the next, the first and the last beyond it).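

Among these compounds, this gives the first single-change reading at this position: in this assay, going from isopropyl to ethyl is a 1.4-fold higher number from compound 1 to compound 3 (0.13 log units; within the scatter). The loss of one methyl, a single carbon with no ring, no hydrogen-bond donor or acceptor and no net charge, therefore produces no change that can be separated from the scatter. Both the branched isopropyl group and the ethyl group are thus compatible with values in the same range in this assay, although no measurement at hand explains this result.

This single pair does not show how far that flat response extends, since it covers only isopropyl and ethyl on the shared core. Still open, from the compounds shown here alone, is whether a methyl group, a longer chain such as butyl, or a chain ending in an amine, placed at this same position on an otherwise unchanged compound 1, would stay within the scatter or give a step beyond it.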